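Trifluoromethyl on compound 1: working notes

The compounds below may be only part of what the source reports. "The series", "measured", "known", "first", "only" and "open" are said of these compounds alone.

Measured in a functional assay on the whole organism (strain Sprague-Dawley) for inhibition, with Rattus norvegicus as the target, with a stated time of 10 min; a lower number here means that less compound is needed, a higher number that more compound is needed for the effect:
- compound 1 `O=C(O)c1cnc(-c2ccccc2)[nH]c1=O`: 50 mg/kg
- compound 2 `COc1ccccc1-c1ncc(C(=O)O)c(=O)[nH]1`: 10 mg/kg

Compound 1 holds the higher of the two numbers in this assay. Compound 3 `O=C(O)c1cnc(-c2cccc(C(F)(F)F)c2)[nH]c1=O` is not yet measured and differs from compound 1 by trifluoromethyl in place of hydrogen on an aromatic carbon. Going by the values given here, the only measured step is a 5.0-fold lower number from compound 1 to compound 2 (0.70 log units; beyond the scatter), with methoxy in place of hydrogen on an aromatic carbon. Among the compounds with values here, it bears only loosely, since no measured compound carries trifluoromethyl. A smaller lowering is therefore expected, with its direction uncertain. The expected step is a 2.0-fold lower number from compound 1 to compound 3 (0.30 log units; within the scatter). For compound 3 the estimate is 25 mg/kg, with an expected range of 8 mg/kg to 70 mg/kg.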

Compound 3, dose for 50% inhibition: 33 mg/kg
Beside the measured number, compound 3's estimate is 1.3-fold (0.12 log units) below it; measured number inside the range.
By their numbers in this assay, from the lowest: compound 2; then compounds 3 and 1 (each within the scatter of the next).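

In this assay, trifluoromethyl on an aromatic carbon, meta to a large group, gives a 1.5-fold lower number from compound 1 to compound 3 (0.18 log units; within the scatter) and so does not separate the two compounds. The methoxy change, by contrast, gives a 5.0-fold lower number from compound 1 to compound 2 (0.70 log units; beyond the scatter) as its step, so not every substitution on this aromatic ring stays within the scatter. Nothing on hand offers an explanation for this result.

Still open, as far as these compounds go, is whether an amine or a hydroxyl group at this same place would move the number beyond the scatter. Also open, from the compounds shown here alone, is how trifluoromethyl behaves on the other carbons of this ring.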